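Aryl against methyl on the ring amine nitrogen: compound 3

The source may report more compounds than this note shows. Statements on the series, on what has been measured and on what is new or still open speak of the compounds shown alone.

For the measured compounds named here, the two measured members are compound 1 `O=C1NC(c2ccccc2)(c2ccccc2)C(=O)N1CN1CCN(c2ccccc2)CC1` and compound 2 `CN1CCN(CN2C(=O)NC(c3ccccc3)(c3ccccc3)C2=O)CC1`. Going by the values given here, in a functional assay on the whole organism (strain CD1) with Mus musculus as the target, in the maximal electroshock model, with a stated time of 0.5 h (on this read-out higher numbers stand for an effect only at larger amounts of compound and lower numbers for an effect already at smaller amounts), compound 1 gives 300 mg/kg, while compound 2 gives 10 mg/kg and so stands at the lowest of the two numbers known. Among the compounds with values here, the single measured step is a 30-fold lower number from compound 1 to compound 2 (1.48 log units; beyond the scatter), a change of methyl in place of phenyl on an amine nitrogen in a ring.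

Compound 3 `O=C1NC(c2ccccc2)(c2ccccc2)C(=O)N1CN1CCN(c2cccc(C(F)(F)F)c2)CC1` is not yet measured. It differs from compound 2 as follows: 3-(trifluoromethyl)phenyl in place of methyl on an amine nitrogen in a ring. Within the data shown here, the only step that bears on this change is a 30-fold lower number from compound 1 to compound 2 (1.48 log units; beyond the scatter), and it runs in the opposite sense: with phenyl on an amine nitrogen in a ring the number was far higher than with methyl. Compound 3 puts an aryl group back on that nitrogen, now with a trifluoromethyl on it, so a step of roughly that size toward a higher number is expected, the added group being the unknown. The expected step is a 20-fold higher number from compound 2 to compound 3 (1.30 log units; beyond the scatter). Compound 3 is therefore estimated at 200 mg/kg, with a range from 50 mg/kg to 600 mg/kg.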

Compound 3, minimum effective dose: 300 mg/kg
The estimate for compound 3 lay 1.5-fold (0.18 log units) below the measured number; the range from low to high includes it.
By their numbers in this assay, from the lowest: compound 2; then compounds 1 and 3 (each within the scatter of the next).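

With a second aryl compound in hand, the change on the amine nitrogen in a ring can be read in this assay from both sides: 3-(trifluoromethyl)phenyl in place of methyl gives a 30-fold higher number from compound 2 to compound 3 (1.48 log units; beyond the scatter) and is as large as the earlier step in the other sense, a 30-fold lower number from compound 1 to compound 2 (1.48 log units; beyond the scatter) (read in reverse, the same size). Trifluoromethyl in place of hydrogen on an aromatic carbon of that aryl group gives no change at the digits printed from compound 1 to compound 3 (within the scatter) (so the added group separates the two aryl compounds by nothing that can be read here), and the low number of compound 2 is not approached by either of them. Among these compounds, the large difference follows the swap between methyl and an aryl group on that nitrogen, while the substituent on the aryl group leaves the number in place; nothing measured on these compounds explains either finding.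

On these data alone, whether the low number belongs to methyl alone, or also holds for hydrogen, ethyl or a longer chain on that nitrogen, remains open. As far as these compounds go, it is equally open whether an amine or a carboxylic acid on the phenyl would move the number at all.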